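The source may hold more compounds than are shown below. What is called first, only, known or untested is meant among the compounds shown, and "the series" means these compounds.

Compound 1 `C=C(CC)C(=O)c1ccc(OCc2nc(-c3ccc([N+](=O)[O-])cc3)cs2)c(C)c1C`: 4.4% in an assay on HL-60 cells for inhibition of glutathione S-transferase P (Homo sapiens), read by spectrophotometry, tested at 5 uM; a lower number here means less inhibition, a higher number more inhibition at the concentration tested (going by the name of the read-out)
Compound 2 `C=C(CC)C(=O)c1ccc(OCc2nc(-c3ccc4ccccc4c3)cs2)c(C)c1C`: 0%
Compound 3 `C=C(CC)C(=O)c1ccc(OCc2nc(-c3ccc([N+](=O)[O-])cc3)cs2)c(Cl)c1Cl`: 8.1%

Of the compounds shown here, three have been measured in this assay. From compound 1 to compound 2 the change is naphthalen-2-yl in place of 4-nitrophenyl on an aromatic carbon, and it made a step of a number 4.4 percentage points lower from compound 1 to compound 2 (within the scatter). The cores of compound 3 and compound 1 differ in more than one place; that difference is not broken down here. Compound 4 `C=C(CC)C(=O)c1ccc(OCc2nc(-c3ccc4ccccc4c3)cs2)c(Cl)c1Cl` carries the same change on the core of compound 3: naphthalen-2-yl in place of 4-nitrophenyl on an aromatic carbon, at the same place in the same words. Since the earlier step lay within the scatter and compound 3 gives 8.1%, a step of similar size is expected. Compound 4 is therefore expected at 4%, between 0% and 12%, an expected step of a number 4.1 percentage points lower from compound 3 to compound 4 (within the scatter) in this assay.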

Compound 4, a percentage reported as inhibition, at one concentration (the size of the read-out at that concentration, not a potency): 4.3%
Beside the measured number, compound 4's estimate is 0.3 percentage points below it; measured number inside the range.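

In this assay, naphthalen-2-yl in place of 4-nitrophenyl on the core of compound 3 gave a number 3.8 percentage points lower from compound 3 to compound 4 (within the scatter). The same change gave matching steps on the two cores: the same change on two cores in this assay, a number 4.4 percentage points lower (within the scatter) from compound 1 to compound 2 and a number 3.8 percentage points lower (within the scatter) from compound 3 to compound 4, 0.6 percentage points apart, within the scatter of two such steps. This shows that, on these two cores, the change carried over without a detectable difference, but since neither step stands clear of the scatter, it does not show that the change has any real effect on the read-out, or that it would carry over to any other core.

Going by these compounds, it remains open whether an amine or a carboxylic acid on that aromatic carbon, in place of these two aromatic groups, would give a step beyond the scatter. Also open, on these data alone, is how the change would behave on a core with a longer chain in place of the ethyl group of the shared ketone side chain.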